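Changing the chain on compound 2

The source may hold more compounds than are shown below. What is called first, only, known or untested is meant among the compounds shown, and "the series" means these compounds.

Compound 1, `CCn1nc(-c2cccnc2)c2ccccc2c1=O`: 87%
Compound 2, `CC(=O)OCCn1nc(-c2cccnc2)c2ccccc2c1=O`: 32%

In an assay on isolated protein (Oryctolagus cuniculus) with Thromboxane-A synthase (Homo sapiens) as the target, tested at 1 uM (a higher number here means more inhibition at the concentration tested (going by the name of the read-out), a lower number less inhibition), compound 1 gives 87%, and compound 2 gives 32%. Compound 2 stands lowest of the two numbers; its nearest neighbour is compound 1, and the step of a number 55 percentage points lower from compound 1 to compound 2 (beyond the scatter) lies beyond the scatter. Compound 3, `O=c1c2ccccc2c(-c2cccnc2)nn1CCCCSc1ncccn1`, differs from compound 2 by 2-((pyrimidin-2-yl)sulfanyl)ethyl in place of acetoxy on a saturated chain carbon, two bonds along the chain from an aromatic nitrogen. Going by the values given here, the only measured step that bears on this change is a number 55 percentage points lower from compound 1 to compound 2 (beyond the scatter): it covers the entry of acetoxy, and in compound 3 acetoxy leaves again. Nothing measured covers the 2-((pyrimidin-2-yl)sulfanyl)ethyl group that enters, so the second half of the change is open. For compound 3 an upward step a number 28 percentage points higher from compound 2 to compound 3 (beyond the scatter) in this assay is therefore expected, with wide uncertainty. Compound 3 is estimated at 60%, in a range from 25% to 90%.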

Compound 3, a percentage reported as inhibition, at one concentration (the size of the read-out at that concentration, not a potency): 96%
Beside the measured number, compound 3's estimate is 36 percentage points below it; the measured number lies above the stated range.
By their numbers in this assay, from the lowest: compound 2; then compounds 1 and 3 (each within the scatter of the next).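

In this assay, replacing acetoxy with 2-((pyrimidin-2-yl)sulfanyl)ethyl gives a number 64 percentage points higher from compound 2 to compound 3 (beyond the scatter), so the low number of compound 2 does not hold for every group on this saturated chain carbon, two bonds along the chain from an aromatic nitrogen. Set against hydrogen at the same place, the same group gives a number 9 percentage points higher from compound 1 to compound 3 (within the scatter), so a substituent carrying a six-membered aromatic ring with 2 hetero atoms can stand here and leave the number level with that of compound 1. Nothing available accounts for the wide gap between acetoxy and this group.

Going by these compounds, it remains open whether the pyrimidine ring, the sulfur or the chain itself matters most for the result. Also open, on these data alone, is how a hydroxyl, an amine or a carboxylic acid would read at this place.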